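The source may report more compounds than this note shows. Statements on the series, on what has been measured and on what is new or still open speak of the compounds shown alone.

Compound 1 `CCCc1c(OCCCCOc2ccc(-c3nn[nH]n3)cc2)ccc(C(C)=O)c1O` is the starting point. In an assay on isolated protein for binding affinity to metabotropic glutamate receptor 2 (Homo sapiens), read by GTPgammaS binding (a lower number here means that less compound is needed, a higher number that more compound is needed for the effect), compound 1 gives 348 nM, the lowest of the three numbers measured. Compound 2 `CCCc1c(OC(C)CCCOc2ccc(-c3nn[nH]n3)cc2)ccc(C(C)=O)c1O` gives 918 nM in this assay, and compound 3 `CC(=O)c1ccc(OCCCCOc2ccc(-c3nn[nH]n3)cc2)c(Br)c1O` gives 878 nM. Compound 4 `CCCc1c(OCCCCOc2ccc(C(=O)NS(C)(=O)=O)cc2)ccc(C(C)=O)c1O` differs from compound 1 only at one end of the chain: (methylsulfonyl)carbamoyl in place of 2H-tetrazol-5-yl on an aromatic carbon. Neither measured step touches that end. The step of a 2.6-fold higher number from compound 1 to compound 2 (0.42 log units; beyond the scatter) alters the chain itself, and the step of a 2.5-fold higher number from compound 1 to compound 3 (0.40 log units; beyond the scatter) alters the other aromatic ring; each of them weakened binding modestly. Among the compounds with values here, with no step bearing directly on the exchanged group, a modest weakening is expected for compound 4, a step of a 1.9-fold higher number from compound 1 to compound 4 (0.27 log units; within the scatter). Compound 4 is therefore estimated at 650 nM, within 200 nM to 2200 nM.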

Compound 4, half-maximal effective concentration: 1040 nM
For compound 4 the middle estimate is 1.6-fold (0.20 log units) below the measured one; the measured number falls inside the stated range.
By their numbers in this assay, from the lowest: compound 1; then compounds 3, 2 and 4 (each within the scatter of the next).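

Within the data shown here, until now, no step had touched the 2H-tetrazol-5-yl end of the molecule. In this assay, exchanging it for (methylsulfonyl)carbamoyl gives a 3.0-fold higher number from compound 1 to compound 4 (0.48 log units; beyond the scatter) and so shows that this end influences the number, even though the counts of hydrogen-bond donors and acceptors stay the same. No measurement is available to explain the difference between these two groups.

From the compounds shown here alone, whether a carboxylic acid at this place would give a lower or a higher number stays open. So does the effect of replacing the methyl on the sulfonyl with a phenyl ring.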